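The compounds below may be only part of what the source reports. "The series", "measured", "known", "first", "only" and "open" are said of these compounds alone.

Among the measured compounds shown here, compound 3, with the structure `CCCCCCc1ccc(NC(=O)N[C@H](C)c2ccccc2)cc1`, has the highest of the three numbers measured so far in an ADME assay on the whole organism with Oryza sativa as the target, tested at 1 uM (a lower number here means a stronger effect, a higher number a weaker effect of the compound at the concentration tested), where compound 3 gives 101%. The nearest of the others is compound 1, with the structure `CC(C)c1ccc(NC(=O)N[C@@H](C)c2ccccc2)cc1`; in this assay compound 1 gives 96%, which lies within the scatter of compound 3. The furthest is compound 2, with the structure `CCCCc1ccc(NC(=O)N[C@@H](C)c2ccccc2)cc1`, which in this assay gives 72%.

Compound 4 has the structure `CCCCCCc1ccc(NC(=O)N[C@@H](C)c2ccccc2)cc1` and has not yet been measured. How it differs from compound 3: the two compounds have the same atoms and bonds and differ only in configuration as drawn: 1 of 1 stereo elements differ; a stereocentre at a saturated chain carbon is drawn R in compound 3 and S in compound 4.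

For the measured compounds named here, the only measured step, a number 24 percentage points lower from compound 1 to compound 2 (beyond the scatter), concerns a change of the group on the aromatic carbon and says nothing about the configuration at the chain carbon. Going by the values given here, no measured pair isolates that change, so there is no basis for expecting a step in either direction, and the expectation is a step of a number 11 percentage points lower from compound 3 to compound 4 (beyond the scatter), with a wide range. Compound 4 is therefore estimated at 90%, between 55% and 105%.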

Compound 4, a percentage reported as activity, at one concentration (the size of the read-out at that concentration, not a potency): 100%
For compound 4 the middle estimate is 10 percentage points below the measured one, within the range that was stated.
By their numbers in this assay, from the lowest: compound 2; then compounds 1, 4 and 3 (each within the scatter of the next).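

In this assay, among the compounds shown here, changing the configuration at the saturated chain carbon gives a number 1 percentage points lower from compound 3 to compound 4 (within the scatter), the first reading on this change, and the comparison is a clean one: the fact that compounds 3 and 4 differ only in the configuration as drawn. With the configuration kept as drawn, ethyl in place of hydrogen on a saturated chain carbon, four bonds along the chain from an aromatic carbon, gives a number 28 percentage points higher from compound 2 to compound 4 (beyond the scatter), while swapping the isopropyl group on the aromatic carbon for a hexyl group gives a number 4 percentage points higher from compound 1 to compound 4 (within the scatter). The lower number therefore stays with the butyl group of compound 2 alone, and the number does not move steadily in one direction as the chain grows.

On these data alone, whether configuration at the chain carbon also makes so little difference with a butyl group on the aromatic carbon remains open. A pentyl chain, or an amine at the end of the butyl chain, could show how narrowly the lower number depends on the butyl group.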